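Pyrimidin-2-yl for carbamoyl: notes toward compound 3

The compounds below may be only part of what the source reports. "The series", "measured", "known", "first", "only" and "open" are said of these compounds alone.

Measured so far, in a functional assay for inhibition, with Oryctolagus cuniculus as the target; a lower number here means a stronger inhibitor, a higher number a weaker inhibitor:
compound 1, `CN(C(=O)C[C@@H](N)CCCN=C(N)N)C1CN=C(NC(N)=O)NC1=O`: 170 nM
compound 2, `CN(C(=O)C[C@@H](N)CCCCN)C1CN=C(NC(N)=O)NC1=O`: 2800 nM

Among the compounds with values here, compound 2 has the highest of the two numbers in this assay; its nearest neighbour is compound 1, and the one measured step is a 16-fold higher number from compound 1 to compound 2 (1.22 log units; beyond the scatter), a large step concerning the group on a saturated chain carbon, four bonds along the chain from an amine nitrogen.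

Compound 3, `CN(C(=O)C[C@@H](N)CCCCN)C1CN=C(Nc2ncccn2)NC1=O`, keeps the chain of compound 2 and changes the other end of the shared core: pyrimidin-2-yl in place of carbamoyl on an amine nitrogen.

Within the data shown here, no measured step touches the ureido end of the core; the step from compound 1 to compound 2 concerns a different position and gives no guidance here. Without a comparable pair, the expectation for this assay is wide and without a confident direction. Compound 3 is estimated at 2000 nM, within a range of 400 nM to 10000 nM. This estimate corresponds to an expected step of a 1.4-fold lower number from compound 2 to compound 3 (0.15 log units; within the scatter), which stays close to compound 2 only by default.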

Compound 3, half-maximal inhibitory concentration: 380 nM
Compound 3: middle estimate off by 5.3-fold (0.72 log units), on the high side, outside the stated range (below it).
By their numbers in this assay, from the lowest: compound 1; then compound 3; then compound 2.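

With the chain of compound 2 held constant, pyrimidin-2-yl in place of carbamoyl on an amine nitrogen gives, in this assay, a 7.4-fold lower number from compound 2 to compound 3 (0.87 log units; beyond the scatter), so the ureido end of the shared core also moves the number, which the earlier step on the chain could not show. The carbamoyl group is therefore not required for inhibition at this position: a six-membered aromatic ring with 2 hetero atoms, with 0 hydrogen-bond donors against the 1 of carbamoyl, takes its place and gives the lower number. Nothing on hand separates the contributions of the ring, its nitrogens or the lost carbonyl to this change.

On these data alone, compound 1 and compound 3 differ in two places, so it remains open whether (pyrimidin-2-yl)amino on the chain of compound 1 would add to the chain effect or overlap with it. As far as these compounds go, it is equally open whether the ring nitrogens matter at this position, which a phenyl or pyridin-2-yl group on the same amine nitrogen would address, and whether an acetyl group would behave like carbamoyl or like pyrimidin-2-yl.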